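A few compounds are considered here, and "the series" means these few. Any claim that something is new, unique, unknown or untested is made for them only; others in the source may bear on it.

In a functional assay on A549 cells (Homo sapiens) for antiproliferative activity, read by sulforhodamine B assay, with a stated time of 72 h (on this read-out higher numbers stand for weaker inhibition and lower numbers for stronger inhibition), compound 1 `CC(=O)Oc1cc2c(CCC=C(C)C)c(C)ccc2cc1C(C)C` gives 25500 nM, compound 2 `CC(=O)Oc1cc2c(CC[C@H](O)C(C)(C)O)c(C)ccc2cc1C(C)C` gives 50500 nM and compound 3 `CC(=O)Oc1cc2c(CC[C@@H]3OC(C)(C)OC3(C)C)c(C)ccc2cc1C(C)C` gives 68500 nM. Compound 3 therefore stands apart from only one of the others, as the data show a 2.7-fold higher number from compound 1 to compound 3 (0.43 log units; beyond the scatter) but only a 1.4-fold higher number from compound 2 to compound 3 (0.13 log units; within the scatter). Compound 4 `CC(=O)Oc1cc2c(CC[C@H]3OC(C)(C)OC3(C)C)c(C)ccc2cc1C(C)C` has a single structural difference from compound 3: the two compounds have the same atoms and bonds and differ only in configuration as drawn: 1 of 1 stereo elements differ; a stereocentre at a saturated ring carbon is drawn S in compound 3 and R in compound 4. For the measured compounds named here, no measured pair tests a change of configuration, so the evidence is indirect. Even the changes of group gave small steps, with a 2.0-fold higher number from compound 1 to compound 2 (0.30 log units; within the scatter) alongside the two above. No change beyond the scatter is therefore expected, and the estimated step is a 1.1-fold lower number from compound 3 to compound 4 (0.06 log units; within the scatter). Compound 4 is expected at 60000 nM, within an estimated range of 30000 nM to 115000 nM.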

Compound 4, half-maximal inhibitory concentration: 28900 nM
Compound 4: the middle estimate sits 2.1-fold (0.32 log units) above what was measured, outside the stated range (below it).
By their numbers in this assay, from the lowest: compounds 1, 4, 2 and 3 (each within the scatter of the next, the first and the last beyond it).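

The change from S to R at the saturated ring carbon gives a 2.4-fold lower number from compound 3 to compound 4 (0.37 log units; beyond the scatter), and this step can be put down to configuration alone because of one fact: the fact that compounds 3 and 4 differ only in the configuration as drawn. With the R centre, 2,2,5,5-tetramethyl-1,3-dioxolan-4-yl shows a 1.1-fold higher number from compound 1 to compound 4 (0.05 log units; within the scatter) and a 1.7-fold lower number from compound 2 to compound 4 (0.24 log units; within the scatter), so the earlier rise beyond the scatter belongs to the S form only.

Open, as far as these compounds go, is whether the other configuration of compound 2 would shift its number, and whether an amine, a carboxylic acid or a longer chain here would give clearly stronger inhibition than compound 1.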